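Aryl swaps on a shared core: compound 3 to compound 4

The source may hold more compounds than are shown below. What is called first, only, known or untested is meant among the compounds shown, and "the series" means these compounds.

Of the compounds shown here, three sharing one core have been measured in a functional assay on HeLa cells (Homo sapiens) for inhibition, read by CCK-8 assay, with a stated time of 48 h; on this read-out higher numbers stand for weaker inhibition and lower numbers for stronger inhibition. Compound 1 `COc1cc(-c2ccnc3cc(-c4ccc5cc[nH]c5c4)nn23)cc(OC)c1OC` gives 125 nM, compound 2 `COc1ccc(-c2cc3nccc(-c4cc(OC)c(OC)c(OC)c4)n3n2)cc1F` gives 236 nM, and compound 3 `COc1cc(-c2ccnc3cc(-c4c[nH]c5ccccc45)nn23)cc(OC)c1OC` gives 195 nM, the second highest of the three numbers. Compound 4 `COc1cc(-c2ccnc3cc(-c4ccc5cnn(C)c5c4)nn23)cc(OC)c1OC` differs from compound 3 by 1-methyl-1H-indazol-6-yl in place of 1H-indol-3-yl on an aromatic carbon. For the measured compounds named here, the steps that bear on it are all aryl exchanges at the same place: a 1.6-fold higher number from compound 1 to compound 3 (0.19 log units; within the scatter), a 1.9-fold higher number from compound 1 to compound 2 (0.28 log units; within the scatter) and a 1.2-fold lower number from compound 2 to compound 3 (0.08 log units; within the scatter), each within the scatter. Another exchange of this kind is therefore expected to give no step beyond the scatter in this assay, so compound 4 is estimated at 180 nM, within 80 nM to 400 nM, an expected change of a 1.1-fold lower number from compound 3 to compound 4 (0.03 log units; within the scatter).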

Compound 4, half-maximal inhibitory concentration: 97 nM
Estimate against measurement, compound 4: 1.9-fold (0.27 log units) above; measured number inside the range.
By their numbers in this assay, from the lowest: compounds 4, 1, 3 and 2 (each within the scatter of the next, the first and the last beyond it).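

In this assay, this place on the five-membered aromatic ring gives its first step beyond the scatter, a modest one (a 2.4-fold lower number from compound 2 to compound 4 (0.39 log units; beyond the scatter)) with 1-methyl-1H-indazol-6-yl replacing 3-fluoro-4-methoxyphenyl. The exchanges against the two indolyl groups stay within the scatter (a 2.0-fold lower number from compound 3 to compound 4 (0.30 log units; within the scatter); a 1.3-fold lower number from compound 1 to compound 4 (0.11 log units; within the scatter)), so a group without a hydrogen-bond donor stands level with both donor-bearing groups here. Nothing available explains the modest step. Still open, as far as these compounds go, is how an amine or a carboxylic acid on the 1-methyl-1H-indazol-6-yl group would behave, and whether morpholine could replace the aromatic group at this place.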